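Chloroacetamide benzoxazoles: methyl to fluoro on the fused ring

This account rests on a few compounds, and the source may have more. Where it says the series, first, only, none or still open, it means among the compounds named here.

Working notes on the series. Compound 3 `Cc1ccc2oc(-c3ccc(NC(=O)CCl)cc3)nc2c1` gives 4040 nM in a functional assay on C6 cells (Rattus norvegicus) for cytotoxicity, read by MTT assay, with a stated time of 24 h; a lower number here means a stronger inhibitor, a higher number a weaker inhibitor. Among the numbers shown it stands highest; the nearest is compound 1 `Cc1ccc2oc(-c3ccc(NC(=O)CN4CCN(CCN(C)C)CC4)cc3)nc2c1`, which in this assay gives 1630 nM, a gap beyond the scatter. Compound 2 `Cc1cc(-c2nc3cc(F)ccc3o2)ccc1NC(=O)CCl` reaches only a limit, > 100000 nM (the limit of > 100000 nM in this assay, at which 1 of the 3 values shown sits), and no number is known for it in this assay.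

The next entry, compound 4 `O=C(CCl)Nc1ccc(-c2nc3cc(F)ccc3o2)cc1`, differs from compound 3 in one place: fluoro in place of methyl on an aromatic carbon. For the measured compounds named here, no measured pair with this same change exists, so the size of the step is open. Since the only fluoro-bearing compound shown, compound 2, sits at a limit, and compound 3 is already the weaker of the two numbered compounds, the expected direction for compound 4 is towards a weaker inhibitor, by a step somewhat beyond the scatter. The expected step of a 2.2-fold higher number from compound 3 to compound 4 (0.35 log units; beyond the scatter) is a weakening. The estimate for compound 4 in this assay is 9000 nM, with a range from 2500 nM to 40000 nM.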

Compound 4, half-maximal inhibitory concentration: 2990 nM
Beside the measured number, compound 4's estimate is 3.0-fold (0.48 log units) above it, within the range that was stated.
By their numbers in this assay, from the lowest: compounds 1, 4 and 3 (each within the scatter of the next, the first and the last beyond it). At a limit, above all of these: compound 2.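

In this assay, fluoro in place of methyl on an aromatic carbon of the six-membered aromatic ring gives a 1.4-fold lower number from compound 3 to compound 4 (0.13 log units; within the scatter), so the two groups are not told apart at this position. The methyl on an aromatic carbon that sets compound 2 apart matters far more: hydrogen in its place gives an at least 33-fold lower number from compound 2 to compound 4 (1.52 log units; beyond the scatter), with fluoro present in both compounds. The value of compound 2 is a limit and not a number, so this step has only a lower bound: the limit of > 100000 nM in this assay, at which 1 of the 4 values shown sits.

The compounds shown leave open whether a methoxy group or an amine on the same aromatic carbon would stay within the scatter of compound 4. On these data alone, it also remains open whether hydrogen in place of the other methyl would give a step of similar size with methyl rather than fluoro on the six-membered aromatic ring.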